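The compounds below may be only part of what the source reports. "The series", "measured", "known", "first", "only" and "open" are said of these compounds alone.

Measured so far:
compound 1, `CC(C)c1ccc(-n2nc(-c3ccc(C(F)(F)F)cc3O)nc2-c2ccccc2O)cc1`, 100%
compound 2, `CC(C)(C)c1ccc(-n2nc(-c3ccc(C(F)(F)F)cc3O)nc2-c2ccccc2O)cc1`, 77.8%

In a functional assay on PC-12 cells (Rattus norvegicus) for cytotoxicity, read by MTT assay, with stated times of 2 h and 24 h, tested at 5 uM (a higher number here means a stronger effect of the compound at the concentration tested, a lower number a weaker effect), compound 2 gives the lower of the two numbers; its nearest neighbour is compound 1, a number higher by the step of a number 22.2 percentage points lower from compound 1 to compound 2 (beyond the scatter). The unmeasured compound 3, `Oc1cc(C(F)(F)F)ccc1-c1nc(-c2ccccc2O)n(-c2ccc(F)cc2)n1`, differs from compound 2 in one place: fluoro in place of tert-butyl on an aromatic carbon.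

Among the compounds with values here, only one measured step bears on this change, and only loosely. The step of a number 22.2 percentage points lower from compound 1 to compound 2 (beyond the scatter) shows that enlarging the group on this phenyl ring from isopropyl to tert-butyl lowered the number by a modest amount, beyond the scatter. Within the data shown here, the change to compound 3 goes the other way in size, replacing tert-butyl with the much smaller fluoro, but no measured pair shows a group as small as fluoro at this position, so the direction can be argued only by analogy.

On that basis a modest rise in this assay is expected for compound 3, as the step of a number 7.2 percentage points higher from compound 2 to compound 3 (within the scatter). Compound 3 is therefore estimated at 85%, within a range from 55% to 100%.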

Compound 3, a percentage reported as activity, at one concentration (the size of the read-out at that concentration, not a potency): 86.7%
Compound 3: the middle estimate sits 1.7 percentage points below what was measured; the measured number falls inside the stated range.
By their numbers in this assay, from the lowest: compounds 2 and 3 (each within the scatter of the next); then compound 1.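

In this assay, the exchange of 4-(tert-butyl)phenyl for 4-fluorophenyl comes out as a number 8.9 percentage points higher from compound 2 to compound 3 (within the scatter), so at this place on the ring a group of four heavy atoms and a group of one heavy atom cannot be told apart in this read-out. The comparison with the isopropyl group is clearer, with fluoro in its place giving a number 13.3 percentage points lower from compound 1 to compound 3 (beyond the scatter). Isopropyl is smaller than tert-butyl and larger than fluoro, yet compound 1 has the highest number of the three, so these compounds do not fall along a simple line running from the smallest group to the largest.

No measurement at hand explains why the three compounds fall in this way. The compounds shown leave open whether plain hydrogen, a methoxy group, an amine or a longer carbon chain at this place would stand with compound 1 or with the pair of compound 2 and compound 3, and so whether isopropyl is a special case or part of a wider pattern.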